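The source may hold more compounds than are shown below. What is called first, only, known or untested is meant among the compounds shown, and "the series" means these compounds.

Measured so far:
- Compound 1, `CC1=C(SCCCO)C(=O)c2ccccc2C1=O`. In a functional assay on NPC-TW-039 cells (Homo sapiens) for inhibition, with NPC-TW-039 (Mus musculus) as the target (a higher number here means a weaker inhibitor, a lower number a stronger inhibitor), compound 1 gives > 10000 nM, which is a limit of the assay rather than a number.
- Compound 2, `CC1=C(SCCCCO)C(=O)c2ccccc2C1=O`. In this assay compound 2 gives > 10000 nM, again only a limit of the assay.

Compound 1 therefore stands at a limit and nowhere more precise; neither value gives it a measured position. For the measured compounds named here, the single measured step, a step that the two limits leave unreadable from compound 1 to compound 2, is a hydroxymethyl in place of a hydroxy on a saturated chain carbon, three bonds along the chain from a sulfur, and its size stays hidden because of the limit of > 10000 nM in this assay, at which 2 of the 2 values shown sit.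

Compound 3, `CC1=C(SCC(C)O)C(=O)c2ccccc2C1=O`, has not yet been measured. It differs from compound 1 by 1-hydroxyethyl in place of 2-hydroxyethyl on a saturated chain carbon bound to a sulfur; cut one bond further out, the same change reads 3-hydroxypropyl to 2-hydroxypropyl. The measured step concerns a different change and is itself unreadable, so it offers no direction and no size for this one. Nothing in the data points to a move beyond the scatter.

Compound 3 is thus expected to give 15000 nM, in the range 5000 nM to 50000 nM, most likely as a limit again. The estimated step that the limit leaves unreadable from compound 1 to compound 3 is no more than an expectation.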

Compound 3, half-maximal inhibitory concentration: > 10000 nM
Compound 3 was reported as a limit; the forecaster's own chance of this, stated with the estimate: 85%; the middle value is on the limit's open side.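

In this assay compound 3 gives > 10000 nM, again a limit of the assay. For the compounds shown here, no step among compound 1, compound 2 and compound 3 can be read, because all three stop at the same boundary: the limit of > 10000 nM in this assay, at which 3 of the 3 values shown sit. The compounds shown leave open whether changing the hydroxy-bearing chain alters inhibition at all.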